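The source may hold more compounds than are shown below. What is called first, only, known or untested is meant among the compounds shown, and "the series" means these compounds.

In a functional assay on NCI-H2228 cells (Homo sapiens) for inhibition, read by CellTiter-Glo, with a stated time of 96 h (on this read-out higher numbers stand for weaker inhibition and lower numbers for stronger inhibition), compound 1 `CC(C)S(=O)(=O)c1nn(C)cc1Nc1nc(Nc2ccc(C3CCN(C)CC3)cc2OC2CC2)ncc1Cl` gives 36 nM and compound 2 `CC(C)S(=O)(=O)c1nn(C)cc1Nc1nc(Nc2cc(C#N)c(C3CCN(C)CC3)cc2OC2CC2)ncc1Cl` gives 165 nM while compound 3 `Cc1cc(Nc2ncc(Cl)c(Nc3cn(C)nc3S(=O)(=O)C(C)C)n2)c(OC(C)C)cc1C1CNC1` gives 288 nM on the same read-out. Compound 2 therefore sits within the scatter of compound 3 and beyond the scatter of compound 1.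

Compound 4 `CC(C)S(=O)(=O)c1nn(C)cc1Nc1nc(Nc2cc(Cl)c(C3CCN(C)CC3)cc2OC2CC2)ncc1Cl` differs from compound 2 in one place: chloro in place of cyano on an aromatic carbon, ortho to a 1-methylpiperidin-4-yl group and para to a cyclopropyloxy group. The counted difference is chloro in place of cyano on an aromatic carbon for this change.

For the measured compounds named here, the one measured step at this aromatic carbon is a 4.6-fold higher number from compound 1 to compound 2 (0.66 log units; beyond the scatter) with cyano in place of hydrogen, a modest step. Compound 3 differs in several places and offers no direct comparison. Going by the values given here, no chloro compound has been measured, so the expectation rests on that single step.

In this assay a modest move toward a lower number is expected once the cyano leaves. The expected step is a 1.9-fold lower number from compound 2 to compound 4 (0.29 log units; within the scatter) in this estimate. Compound 4 is estimated at 85 nM with an expected range from 30 nM to 240 nM on this read-out.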

Compound 4, half-maximal inhibitory concentration: 103 nM
For compound 4 the middle estimate is 1.2-fold (0.08 log units) below the measured one; measured number inside the range.
By their numbers in this assay, from the lowest: compound 1; then compounds 4, 2 and 3 (each within the scatter of the next, the first and the last beyond it).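

In this assay, replacing the cyano with chloro, ortho to the 1-methylpiperidin-4-yl group, gives a 1.6-fold lower number from compound 2 to compound 4 (0.20 log units; within the scatter) and so does not separate the two groups at this position. Chloro in place of hydrogen gives a 2.9-fold higher number from compound 1 to compound 4 (0.46 log units; beyond the scatter) and cyano in place of hydrogen gives a 4.6-fold higher number from compound 1 to compound 2 (0.66 log units; beyond the scatter), so both groups measured at this carbon stand beyond the scatter of the hydrogen in compound 1, on the side of weaker inhibition. No supporting measurement is available to explain these steps.

From the compounds shown here alone, whether fluoro, methoxy or an amine at this carbon would stay within the scatter of compound 1 remains open. Compound 3 differs from these compounds in several places, so it cannot settle that question.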